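A few compounds are considered here, and "the series" means these few. Any claim that something is new, unique, unknown or untested is made for them only; others in the source may bear on it.

In a functional assay on HepG2 cells (Homo sapiens) for cytotoxicity, read by MTT assay, with a stated time of 48 h (on this read-out lower numbers stand for stronger inhibition and higher numbers for weaker inhibition), compound 3 `COc1cc(-c2nnc3n2NC(c2ccco2)C(C(=O)c2cccs2)S3)cc(OC)c1OC` gives 64100 nM, the lowest of the two numbers shown here. The nearest of them belongs to compound 2 `COc1ccc(C(=O)C2Sc3nnc(-c4cc(OC)c(OC)c(OC)c4)n3NC2c2cccs2)cc1`, which in this assay gives 68000 nM, a gap that lies within the scatter. Compound 1 `COc1cc(-c2nnc3n2NC(c2cccs2)C(C(=O)c2ccccc2)S3)cc(OC)c1OC` sits at the limit of > 100000 nM in this assay, at which 1 of the 3 values shown sits, so its value of > 100000 nM is a limit and not a number.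

Compound 4 `COc1cccc(C(=O)C2Sc3nnc(-c4cc(OC)c(OC)c(OC)c4)n3NC2c2ccco2)c1` has not yet been measured. It differs from compound 3 in a single place: 3-methoxyphenyl in place of thiophen-2-yl on a carbonyl carbon. For the measured compounds named here, only one measured step bears on such a change to the group on the carbonyl carbon, namely an at least 1.4-fold lower number from compound 1 to compound 2 (0.16 log units; that floor lies within the scatter), and even its floor stays within the scatter. A change of the aryl group at that position has therefore shown no effect beyond the scatter in these compounds, and none is expected here either.

The step expected from compound 3 to compound 4 in this assay is a 1.1-fold higher number from compound 3 to compound 4 (0.04 log units; within the scatter), within the scatter. Compound 4 is accordingly estimated at 70000 nM, with a range from 30000 nM to 160000 nM.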

Compound 4, half-maximal inhibitory concentration: > 100000 nM
Compound 4: only a limit was reported; the forecaster's own chance of this, stated with the estimate: 30%; middle value at least 1.4-fold (0.15 log units) from the limit.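

In this assay, going by these compounds, the change on the carbonyl carbon from thiophen-2-yl to 3-methoxyphenyl gives an at least 1.5-fold higher number from compound 3 to compound 4 (0.19 log units; that floor lies within the scatter), so this position now has a step toward weaker inhibition, and its true size remains unknown. The earlier step at this position, an at least 1.4-fold lower number from compound 1 to compound 2 (0.16 log units; that floor lies within the scatter), ran toward a lower number, so the two steps point in opposite directions, yet neither floor lies beyond the scatter and no direction is established for this position. The read-out offers little room to resolve this at the weak end of the series: the limit of > 100000 nM in this assay, at which 2 of the 4 values shown sit.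

The compounds shown leave open how large either step really is. They also leave open whether an amine or a longer alkyl chain on this carbonyl carbon, in place of the aromatic rings, would move the number beyond the scatter.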